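A few compounds are considered here, and "the series" means these few. Any claim that something is new, unique, unknown or untested is made for them only; others in the source may bear on it.

Of the compounds shown here, three of one series have been measured for their effect on PC-12 cells. Compound 1 `O=C(CCCCC1CCSS1)NCc1cn(CCCOc2ccc3cc(-c4ccccc4)c(=O)oc3c2)nn1` in a functional assay on PC-12 cells (Rattus norvegicus) for cytotoxicity, read by MTT assay, with stated times of 3 h and 2 h, tested at 5 uM (a lower number here means a weaker effect, a higher number a stronger effect of the compound at the concentration tested), gives 29.8%. Within the data shown here, compound 2 `COc1ccc(-c2cc3ccc(OCCCn4cc(CNC(=O)CCCCC5CCSS5)nn4)cc3oc2=O)cc1` carries methoxy in place of hydrogen on an aromatic carbon and in this assay gives 52.8%; the step of a number 23 percentage points higher from compound 1 to compound 2 (beyond the scatter) is the only single change measured so far. Compound 3 `O=C(CCCCC1CCSS1)NCc1cn(CCCCOc2ccc3cc(-c4ccccc4)c(=O)oc3c2)nn1` in this assay gives 32.8%; the difference between its core and the core of compound 1 is not broken down here, and the two values of compound 1 and compound 3 lie within the usual scatter of each other, so nothing can be said about their order. Against compound 2, compound 3 stands lower by a margin beyond the scatter.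

Compound 4 `COc1ccc(-c2cc3ccc(OCCCCn4cc(CNC(=O)CCCCC5CCSS5)nn4)cc3oc2=O)cc1` has not yet been measured in this assay. It is related to compound 3 by methoxy in place of hydrogen on an aromatic carbon, the same change that turns compound 1 into compound 2, at the same place on the ring. Among the measured compounds shown here, with only one earlier instance, the expectation rests on that single step a number 23 percentage points higher from compound 1 to compound 2 (beyond the scatter) alone. On this basis the step from compound 3 to compound 4 is expected to be a number 20.2 percentage points higher from compound 3 to compound 4 (beyond the scatter), of similar size to the earlier one. Compound 4 is therefore estimated to give 53% in this assay, most likely between 36% and 68%.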

Compound 4, a percentage reported as activity, at one concentration (the size of the read-out at that concentration, not a potency): 44.9%
Estimate against measurement, compound 4: 8.1 percentage points above; measured number inside the range.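

In this assay, methoxy in place of hydrogen, which turns phenyl into 4-methoxyphenyl, gives a number 12.1 percentage points higher from compound 3 to compound 4 (beyond the scatter) and so goes in the same direction on this core as on the core of compound 1. Set side by side, the two steps cannot be told apart in size: the same change on two cores in this assay, a number 23 percentage points higher (beyond the scatter) from compound 1 to compound 2 and a number 12.1 percentage points higher (beyond the scatter) from compound 3 to compound 4, 10.9 percentage points apart, within the scatter of two such steps. Among these compounds, this shows that, across these two cores, the change carried over in direction and that the apparent difference in size between the steps should not be read as real, but it rests on only two pairs and shows neither that the step would hold on any further core nor why the read-out rises.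

The compounds shown leave open whether other groups in the same place on the ring, such as a hydroxyl, a fluorine or an amine, would move the read-out in the same way, and whether methoxy would do so with a shorter or a longer chain than those of compound 1 and compound 3. From the compounds shown here alone, each number is also a reading at a single concentration, so how either step would look at other concentrations remains open.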